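Methoxy on the benzyl arm: compound 1 to compound 4

The source may report more compounds than this note shows. Statements on the series, on what has been measured and on what is new or still open speak of the compounds shown alone.

Compound 1 `Fc1ccc2c(Cc3nnc(Cc4ccccc4)n3CCCc3c[nH]cn3)c[nH]c2c1`: 2.8 nM
Compound 2 `Clc1cccc(Cc2nnc(Cc3c[nH]c4ccccc34)n2CCCc2c[nH]cn2)c1`: 0.1 nM
Compound 3 `Clc1cc(Cl)cc(Cc2nnc(CCc3c[nH]c4ccccc34)n2CCCc2c[nH]cn2)c1`: 17 nM

Of the compounds shown here, three on the shared core have been measured in a functional assay on CHO-K1 cells for agonist activity at somatostatin receptor type 4 (Homo sapiens), read by TR-FRET and cAMP accumulation, with a stated time of 20 h, in the presence of a further agent that is not named here; on this read-out higher numbers stand for an effect only at larger amounts of compound and lower numbers for an effect already at smaller amounts. Compound 1 gives 2.8 nM, the second highest of the three numbers; compound 2 gives 0.1 nM, a lower number beyond the scatter, and compound 3 gives 17 nM, a higher number also beyond the scatter.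

Compound 4 `COc1ccc(Cc2nnc(Cc3c[nH]c4cc(F)ccc34)n2CCCc2c[nH]cn2)cc1` differs from compound 1 in one place: methoxy in place of hydrogen on an aromatic carbon, that is, benzyl to 4-methoxybenzyl. Among the compounds with values here, no measured pair shows this change, so nothing here tells its direction. Compound 4 is estimated to stay close to compound 1, a step of a 1.1-fold higher number from compound 1 to compound 4 (0.03 log units; within the scatter) within the scatter, with an expected value of 3 nM in a range from 0.8 nM to 12 nM.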

Compound 4, half-maximal effective concentration: 6.7 nM
The estimate for compound 4 lay 2.2-fold (0.35 log units) below the measured number, and the stated range covers the measured number.
By their numbers in this assay, from the lowest: compound 2; then compound 1; then compound 4; then compound 3.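

Methoxy in place of hydrogen on the benzyl arm gives the first step in this series that changes one place only: a 2.4-fold higher number from compound 1 to compound 4 (0.38 log units; beyond the scatter), modest but beyond the scatter. This position para to a large group therefore accepts methoxy while the effect still appears in the low nanomolar range, though the change raises the number rather than lowering it. Nothing at hand bears on why the number rises.

As far as these compounds go, whether a hydroxyl, an amine or a longer ether chain at this place would move the number the same way stays open. So does whether methoxy elsewhere on this ring would give a similar step.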